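The source may hold more compounds than are shown below. What is called first, only, known or untested is meant among the compounds shown, and "the series" means these compounds.

Measured compounds in this series:
compound 1 `O=C(NOCc1ccccc1F)c1cn(-c2ccccc2)nc1-c1ccccc1`, 75700 nM
compound 2 `O=C(NOCc1ccccc1Cl)c1cn(-c2ccccc2)nc1-c1ccccc1`, 82100 nM
compound 3 `Cc1ccc(-c2nn(-c3ccccc3)cc2C(=O)NOCc2ccccc2)cc1`, 40800 nM

All three were read in an ADME assay on HEK-293T cells (Homo sapiens) for antiproliferative activity, read by MTT assay, with a stated time of 48 h, in the presence of a further agent that is not named here; on this read-out lower numbers stand for higher toxicity in this test and higher numbers for lower toxicity in this test. Compound 2 gives the highest of the three numbers; its nearest neighbour is compound 1, and compound 3 lies furthest off, yet both gaps stay within the scatter, so no order among the three can be claimed. Among the measured compounds shown here, the one single-point step measured, a 1.1-fold higher number from compound 1 to compound 2 (0.04 log units; within the scatter), was flat.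

Compound 4 `Cc1ccc(-c2nn(-c3ccccc3)cc2C(=O)NOCc2ccccc2Cl)cc1` differs from compound 2 by methyl in place of hydrogen on an aromatic carbon, cut one bond further out: phenyl to 4-methylphenyl. For the measured compounds named here, no measured step isolates this change; compound 3 carries the methyl but also lacks the chloro, so it only shows that a methyl-bearing analogue sits within the scatter of compound 2. The step of a 1.2-fold lower number from compound 2 to compound 4 (0.07 log units; within the scatter) is therefore expected to stay within the scatter. Compound 4 is estimated at 70000 nM, range 35000 nM to 140000 nM.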

Compound 4, half-maximal cytotoxic concentration: 38700 nM
Compound 4: the middle estimate sits 1.8-fold (0.26 log units) above what was measured, and the stated range covers the measured number.
By their numbers in this assay, from the lowest: compounds 4, 3, 1 and 2 (each within the scatter of the next, the first and the last beyond it).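

In this assay, among the compounds shown here, methyl in place of hydrogen para to a large group gives the first single-point step beyond the scatter (a 2.1-fold lower number from compound 2 to compound 4 (0.33 log units; beyond the scatter)), and a modest one. With that methyl present, the step that brings in chloro stays flat (a 1.1-fold lower number from compound 3 to compound 4 (0.02 log units; within the scatter)), so the chloro change shows no effect in this setting either. No measured data at hand bear on the reason for the methyl step.

On these data alone, whether a larger group at that place, such as methoxy, an amine or a carboxylic acid, moves the number further remains open. For the compounds shown here, the methyl step also rests on the single pair carrying chloro, so its size with fluoro remains open too.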